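The source may report more compounds than this note shows. Statements on the series, on what has been measured and on what is new or still open speak of the compounds shown alone.

Measured so far in a functional assay on KOPN-8 cells (Homo sapiens) for antiproliferative activity, with a stated time of 72 h; a higher number here means that more compound is needed for the effect, a lower number that less compound is needed:
compound 1 `COc1ccc(-c2c(Cl)c(=O)c3c(OC)cc(OC)cc3n2S(=O)(=O)c2ccc(OC)cc2)cc1`: 19100 nM
compound 2 `COc1ccc(-c2c(Br)c(=O)c3c(OC)cc(OC)cc3n2S(=O)(=O)c2ccc(OC)cc2)cc1`: 2580 nM
compound 3 `COc1ccc(-c2cc(=O)c3c(OC)cc(OC)cc3n2S(=O)(=O)c2cccc([N+](=O)[O-])c2)cc1`: > 39600 nM

Within the shared core, the one measured step is a 7.4-fold lower number from compound 1 to compound 2 (0.87 log units; beyond the scatter). For compound 3 this assay reports only a limit, > 39600 nM, not a number. Compound 3 therefore stands at the limit of > 39600 nM in this assay, at which 1 of the 3 values shown sits, the weakest position shown.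

Compound 4 `COc1ccc(-c2cc(=O)c3c(OC)cc(OC)cc3n2S(=O)(=O)c2cc(F)c(F)c(F)c2)cc1` is not yet measured. Its change against compound 3 is 3,4,5-trifluorophenyl in place of 3-nitrophenyl on a sulfonyl sulfur. Among the compounds with values here, no measured step touches the group on the sulfonyl sulfur; the step from compound 1 to compound 2 concerns bromo against chloro at an aromatic carbon, in compounds that carry a halogen which compound 3 and compound 4 both lack, so it gives no direct guide here. With compound 3 at a limit, the starting point itself is uncertain, and the change cannot be anchored to any number shown.

The step expected from compound 3 to compound 4 is therefore an at least 1.1-fold lower number from compound 3 to compound 4 (0.05 log units; that floor lies within the scatter), and a further limit-only result is plausible. Compound 4 is estimated at 35000 nM, with a range from 8000 nM to 120000 nM.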

Compound 4, half-maximal effective concentration: > 65500 nM
Compound 4 gave a limit, no number (the forecaster's own chance of this, stated with the estimate: 50%); middle value at least 1.8-fold (0.27 log units) away from the limit.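

In this assay compound 3 gives only a limit, > 39600 nM. Within the data shown here, compound 4 also gives only a limit, > 65500 nM, so no step from compound 3 to compound 4 can be read. Still open, on these data alone, is how 3-nitrophenyl and 3,4,5-trifluorophenyl on the sulfonyl sulfur compare in this assay.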